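A Side-Group Swap on a Strong Inhibitor

The source may hold more compounds than are shown below. What is called first, only, known or untested is meant among the compounds shown, and "the series" means these compounds.

Among the compounds with values here, in a functional assay on cells (Hepatocyte, Rattus norvegicus) for inhibition, read by scintillation counting, with a stated time of 4 h (a higher number here means a weaker inhibitor, a lower number a stronger inhibitor), compound 2 `COc1ccc(CNC(=O)c2nc(-c3ccc(F)cc3)n(CC[C@@H](O)C[C@@H](O)CC(=O)O)c2C2CC2)cc1F` gives 0.2 nM, the lower of the only two numbers available. Compound 3 `O=C(O)C[C@H](O)C[C@H](O)CCn1c(-c2ccc(F)cc2)nc(C(=O)NCc2ccc(F)c(F)c2)c1C1CC1` gives 0.5 nM. Compound 1 `O=C(O)C[C@H](O)C[C@H](O)CCn1c(-c2ccc(F)cc2)nc(C(=O)NCc2ccccc2F)c1C1CC1` offers no guidance, since its entry reads "not determined" (no result reported).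

Compound 4 `Cc1cccc(CNC(=O)c2nc(-c3ccc(F)cc3)n(CC[C@@H](O)C[C@@H](O)CC(=O)O)c2C2CC2)c1` keeps the core of compound 2 and changes one group: 3-methylphenyl in place of 3-fluoro-4-methoxyphenyl on a saturated chain carbon bound to an amide-type nitrogen. In words, 3-methylphenyl takes the place of 3-fluoro-4-methoxyphenyl on a saturated chain carbon bound to an amide-type nitrogen.

Within the data shown here, only one measured step bears on this change: a 2.5-fold higher number from compound 2 to compound 3 (0.40 log units; beyond the scatter). There, fluoro replaces methoxy on the same aromatic ring, and the resulting shift is modest. Compound 4 also gives up the methoxy group, but it gives up the fluoro group too and gains a methyl group. Among the measured compounds shown here, no measured compound carries that methyl group, so the guidance is indirect and rests on a single pair.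

A step of similar modest size, towards a higher number, is therefore expected, and it is estimated as a 2.5-fold higher number from compound 2 to compound 4 (0.40 log units; beyond the scatter). For compound 4 the estimated value is 0.5 nM, with an expected range from 0.15 nM to 1.5 nM.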

Compound 4, half-maximal inhibitory concentration: 0.3 nM
For compound 4 the middle estimate is 1.7-fold (0.22 log units) above the measured one, and the stated range covers the measured number.
By their numbers in this assay, from the lowest: compounds 2, 4 and 3 (each within the scatter of the next, the first and the last beyond it).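

In this assay, 3-methylphenyl can stand in for 3-fluoro-4-methoxyphenyl with no real loss, since the difference is a 1.5-fold higher number from compound 2 to compound 4 (0.18 log units; within the scatter) and the two compounds cannot be told apart. The comparison with the difluoro compound gives the same verdict, at a 1.7-fold lower number from compound 3 to compound 4 (0.22 log units; within the scatter), so compound 4 cannot be separated from either neighbour, even though those two neighbours do differ from each other. The position on the saturated chain carbon bound to an amide-type nitrogen therefore tolerates an aromatic group with no oxygen and no fluorine on it, which the earlier compounds could not show, and nothing given here explains this tolerance.

On these data alone, all three compounds with numbers keep an aromatic ring carrying small groups, so it remains open how a ring bearing an amine or a carboxylic acid would behave at this position. As far as these compounds go, it is equally open what a longer chain leading to the ring would do, and whether a plain phenyl group with no methyl would hold the number as well as compound 4 does.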